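Dimethylamino to Methylpiperazinyl: an Expected Step

This account rests on a few compounds, and the source may have more. Where it says the series, first, only, none or still open, it means among the compounds named here.

Compound 1, `CC1(C)c2[nH]nc(NC(=O)c3ccccc3)c2CN1Cc1cccc(F)c1F`, gives 200 nM in an assay on Sf21 cells for inhibition of high affinity nerve growth factor receptor (Homo sapiens), read by HTRF, with a stated time of 30 min, in the presence of a further agent that is not named here; a lower number here means a stronger inhibitor, a higher number a weaker inhibitor.
Compound 2, `CC1(C)c2[nH]nc(NC(=O)c3ccc(Br)cc3)c2CN1Cc1cccc(F)c1F`, gives 950 nM.
Compound 3, `CN(C)c1ccc(C(=O)Nc2n[nH]c3c2CN(Cc2cccc(F)c2F)C3(C)C)cc1`, gives 69 nM.

Among the three measured compounds, compound 3 has the lowest number in this assay, and both steps to it lie beyond the scatter. The step from its nearest neighbour is a 2.9-fold lower number from compound 1 to compound 3 (0.46 log units; beyond the scatter), and the step from the furthest is a 14-fold lower number from compound 2 to compound 3 (1.14 log units; beyond the scatter).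

Compound 4, `CN1CCN(c2ccc(C(=O)Nc3n[nH]c4c3CN(Cc3cccc(F)c3F)C4(C)C)cc2)CC1`, differs from compound 3 in a single place: 4-methylpiperazin-1-yl in place of dimethylamino on an aromatic carbon. The measured steps that bear on this change are those at the same aromatic carbon: a 4.8-fold higher number from compound 1 to compound 2 (0.68 log units; beyond the scatter), a 2.9-fold lower number from compound 1 to compound 3 (0.46 log units; beyond the scatter) and a 14-fold lower number from compound 2 to compound 3 (1.14 log units; beyond the scatter). Among the compounds with values here, none of them exchanges dimethylamino for another group that also attaches through a nitrogen, so the data give no direct precedent; they show only that this position tolerates substitution in both directions, a modest step either way, and a large one between bromo and dimethylamino. On that basis a step in this assay of no more than the scatter is expected, in no particular direction, with the wider range reflecting the absence of a close precedent.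

Compound 4 is therefore expected to give 60 nM, with a range from 20 nM to 200 nM. The step this estimate means is a 1.2-fold lower number from compound 3 to compound 4 (0.06 log units; within the scatter).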

Compound 4, half-maximal inhibitory concentration: 17 nM
Compound 4: the middle estimate sits 3.5-fold (0.55 log units) above what was measured; measured number outside the range, below it.
By their numbers in this assay, from the lowest: compound 4; then compound 3; then compound 1; then compound 2.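

In this assay, the step at this aromatic carbon, para to a large group, is a 4.1-fold lower number from compound 3 to compound 4 (0.61 log units; beyond the scatter), so a group attached through nitrogen need not stop at dimethylamino: the larger 4-methylpiperazin-1-yl, with its six-membered non-aromatic ring, is not merely accepted here but gives the lowest number of the four compounds. The distance from the other two substituent states also grows, with a 12-fold lower number from compound 1 to compound 4 (1.07 log units; beyond the scatter) and a 56-fold lower number from compound 2 to compound 4 (1.75 log units; beyond the scatter), so the span of this one position now runs from large steps on the side of the hydrogen and bromo compounds to a further modest step beyond dimethylamino. Nothing among the available data accounts for this step.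

The compounds shown leave open which part of the entering group carries the step: the ring itself, its second nitrogen, or the methyl on that nitrogen. As far as these compounds go, how a morpholine, a piperidine or a piperazine without the methyl would stand at this carbon also remains open, as does the effect of a longer chain on the ring nitrogen.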